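Replacing the pyridin-2-yl group of compound 3

The compounds below may be only part of what the source reports. "The series", "measured", "known", "first", "only" and "open" are said of these compounds alone.

Measured in a functional assay on A-375 cells (Homo sapiens) for antiproliferative activity; a higher number here means a weaker inhibitor, a lower number a stronger inhibitor:
compound 1 `O=C(Nc1ccc(-c2ccncc2)cc1)C1CCCN(Cc2ccc(F)c(F)c2)C1`: 600 nM
compound 2 `O=C(Nc1ccc(-c2cccnc2)cc1)C1CCCN(Cc2ccc(F)c(F)c2)C1`: 610 nM
compound 3 `O=C(Nc1ccc(-c2ccccn2)cc1)C1CCCN(Cc2ccc(F)c(F)c2)C1`: 9000 nM

Compound 3 has the highest number of the three. The large steps of a 15-fold higher number from compound 1 to compound 3 (1.18 log units; beyond the scatter) and a 15-fold higher number from compound 2 to compound 3 (1.17 log units; beyond the scatter) set it apart, whereas a 1.0-fold higher number from compound 1 to compound 2 (0.01 log units; within the scatter) shows no separation between the other two.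

The next analogue, compound 4 `O=C(Nc1ccc(-c2ncc[nH]2)cc1)C1CCCN(Cc2ccc(F)c(F)c2)C1`, carries 1H-imidazol-2-yl in place of pyridin-2-yl on an aromatic carbon. Going by the values given here, the measured steps only exchange pyridinyl groups, so they offer no direct precedent for this change and give only a range. So far the high number goes with pyridin-2-yl alone, and leaving that group may recover part of the loss, with compound 1 at 600 nM as the lower reference. In this assay the expected change is moderate, towards a lower number, and uncertain: the estimated step is a 3.6-fold lower number from compound 3 to compound 4 (0.56 log units; beyond the scatter). For compound 4 the estimated value is 2500 nM, with an expected range from 500 nM to 12000 nM.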

Compound 4, half-maximal inhibitory concentration: 19000 nM
Compound 4: middle estimate off by 7.6-fold (0.88 log units), on the low side; the measured number lies above the stated range.
By their numbers in this assay, from the lowest: compounds 1 and 2 (each within the scatter of the next); then compound 3; then compound 4.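

In this assay the change from pyridin-2-yl to 1H-imidazol-2-yl gives a 2.1-fold higher number from compound 3 to compound 4 (0.32 log units; beyond the scatter) and so does not recover the loss: the high number no longer goes with pyridin-2-yl alone. Against the other two pyridinyl groups the gaps are wider, with a 31-fold higher number from compound 2 to compound 4 (1.49 log units; beyond the scatter) and a 32-fold higher number from compound 1 to compound 4 (1.50 log units; beyond the scatter), so among these four compounds both 2-yl groups sit at the high end while pyridin-3-yl and pyridin-4-yl hold the low numbers. No measured evidence on these compounds accounts for this order.

From the compounds shown here alone, whether the link with 2-yl attachment holds for a different attachment of the same ring, as in 1H-imidazol-4-yl, remains open. Also open, going by these compounds, is how 1-methyl-1H-imidazol-2-yl, without the ring hydrogen, or a plain phenyl would compare.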